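Swapping the aryl group on a propylene-linked sulfonamide

A few compounds are considered here, and "the series" means these few. Any claim that something is new, unique, unknown or untested is made for them only; others in the source may bear on it.

Compound 3 `COc1ccc(CNCCCNS(=O)(=O)c2cc(C(F)(F)F)cc(C(F)(F)F)c2)cc1OC` gives 2700 nM in a functional assay on HT-29 cells (Homo sapiens) for inhibition, read by MTT assay, with a stated time of 72 h (a higher number here means a weaker inhibitor of growth, a lower number a stronger inhibitor of growth), level with compound 2 `O=S(=O)(NCCNCc1ccc(-c2ccccc2)cc1)c1cc(C(F)(F)F)cc(C(F)(F)F)c1`, which gives 2700 nM, and well apart from compound 1 `O=S(=O)(NCCNCc1cccc2ccccc12)c1cc(C(F)(F)F)cc(C(F)(F)F)c1`, which gives 16000 nM. Compound 4 `O=S(=O)(NCCCNCc1cccc2ccccc12)c1cc(C(F)(F)F)cc(C(F)(F)F)c1` has not yet been tested in this assay. It differs from compound 3 by naphthalen-1-yl in place of 3,4-dimethoxyphenyl on a saturated chain carbon bound to an amine nitrogen. Going by the values given here, no pair of measured compounds differs in exactly one place, so no step of this kind has been measured. Compound 4 is expected to give a higher number than compound 3, because compound 2 gives 2700 nM while compound 1, carrying the same naphthalen-1-yl group, gives 16000 nM. A step of a 2.6-fold higher number from compound 3 to compound 4 (0.41 log units; beyond the scatter) is expected, beyond the scatter. The estimate for compound 4 is 7000 nM, within 2500 nM to 20000 nM.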

Compound 4, concentration for 50% growth inhibition: 2600 nM
The estimate for compound 4 lay 2.7-fold (0.43 log units) above the measured number, within the range that was stated.
By their numbers in this assay, from the lowest: compounds 4, 2 and 3 (each within the scatter of the next); then compound 1.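

Going by these compounds alone, on a saturated chain carbon bound to an amine nitrogen, naphthalen-1-yl in place of 3,4-dimethoxyphenyl gives a 1.0-fold lower number from compound 3 to compound 4 (0.02 log units; within the scatter) in this assay and is the first single change measured in this set. At this place the two groups cannot be told apart by this read-out, although one has a second aromatic ring and the other carries two oxygens. Nothing measured here accounts for this. Still open, from the compounds shown here alone, is whether a pyridin-3-yl or a plain phenyl group at this place would read the same, and whether a butylene chain would keep the value.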